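This account rests on a few compounds, and the source may have more. Where it says the series, first, only, none or still open, it means among the compounds named here.

Working notes on the series. Three compounds of the shared core have been taken through an ADME assay on CHO cells (Cricetulus griseus) for cytotoxicity, read by MTT assay (a higher number here means a weaker inhibitor, a lower number a stronger inhibitor), so far. Compound 1, `Cc1cc(C)n(-c2nc(-c3ccc(NS(C)(=O)=O)cc3)cc(=O)[nH]2)n1`, gives > 50000 nM in this assay; this is a limit of the assay and not a number. Compound 2, `Cc1cc(C)n(-c2nc(-c3ccc(F)cc3)c(C(N)=O)c(=O)[nH]2)n1`, has "not determined" (no result reported) in this assay. Compound 3, `Cc1cc(-c2ccccc2)n(-c2nc(C(F)(F)F)cc(=O)[nH]2)n1`, gives > 50000 nM in this assay, again a limit rather than a number. For the measured compounds named here, compound 3 therefore stands at the limit of this assay, with one further value at the same limit and one entry without a number, so no step between measured compounds can be drawn. Going by the values given here, the only evidence on hand is the limit of > 50000 nM in this assay, at which 2 of the 3 values shown sit.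

Compound 4, `COCCNc1cc(C)nn1-c1nc(C(F)(F)F)cc(=O)[nH]1`, has not yet been measured. It differs from compound 3 in one place: (2-methoxyethyl)amino in place of phenyl on an aromatic carbon. With every numbered value of the series sitting at the limit, the expected step that the limit leaves unreadable from compound 3 to compound 4 is none beyond the scatter. Compound 4 is accordingly estimated at 60000 nM in this assay, within a range from 30000 nM to 150000 nM, and the most probable outcome is that this assay again returns only a limit for compound 4.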

Compound 4, half-maximal inhibitory concentration: 17000 nM
Beside the measured number, compound 4's estimate is 3.5-fold (0.55 log units) above it; measured number outside the range, below it.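

Replacing phenyl with (2-methoxyethyl)amino on an aromatic carbon of the five-membered aromatic ring, next to the ring nitrogen, gives an at least 2.9-fold lower number from compound 3 to compound 4 (0.46 log units; beyond the scatter) in this assay, so this position can move the read-out beyond the scatter. Compound 3 carries only a limit, which makes the step a bound and leaves its full size unknown. Compound 4 is the only compound shown with a number in this assay, so the change takes the series from the assay limit to a measurable value, while the other values stand as follows: the limit of > 50000 nM in this assay, at which 2 of the 4 values shown sit.

A single pair cannot separate the contributions of the linking nitrogen, the ether oxygen and the loss of the aromatic ring, so a simple methylamino group, a 2-hydroxyethylamino chain, a longer alkoxyalkylamino chain or a morpholine at this position would be needed to tell them apart. For the compounds shown here, it also remains open whether the same change gives a similar step with a group other than trifluoromethyl on the shared core, and no other step can yet be read.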